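A few compounds are considered here, and "the series" means these few. Any claim that something is new, unique, unknown or untested is made for them only; others in the source may bear on it.

Measured so far in an ADME assay on cells (Splenocyte, Mus musculus, strain BALB/c) for cytotoxicity, read by thymidine incorporation, with a stated time of 24 h; on this read-out lower numbers stand for stronger inhibition and higher numbers for weaker inhibition: compound 1 `COc1cc(/C=N/NC(=O)CCN2CCN(c3ccnc4cc(Cl)ccc34)CC2)ccc1OC(C)C` gives 8800 nM, compound 2 `O=C(CCN1CCN(c2ccnc3cc(Cl)ccc23)CC1)N/N=C/c1ccccc1` gives 300 nM, and compound 3 `O=C(CCN1CCN(c2ccnc3cc(Cl)ccc23)CC1)N/N=C/c1ccc(Cl)cc1` gives 200 nM.

Within this small set, compound 3 lies at the low end of the numbers. The gap to compound 1 is large, a 44-fold lower number from compound 1 to compound 3 (1.64 log units; beyond the scatter), and beyond the scatter. The gap to compound 2, however, a 1.5-fold lower number from compound 2 to compound 3 (0.18 log units; within the scatter), is within the scatter, so compound 2 and compound 3 cannot be told apart on this assay.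

The next compound, compound 4 `O=C(CCN1CCN(c2ccnc3cc(Cl)ccc23)CC1)N/N=C/c1ccccc1O`, is not yet measured. It differs from compound 3 in one place: 2-hydroxyphenyl in place of 4-chlorophenyl on a carbon with a double bond to nitrogen. Within the data shown here, two measured steps bear on this. Exchanging the ring hydrogen for chloro, a 1.5-fold lower number from compound 2 to compound 3 (0.18 log units; within the scatter), hardly moved the number. Exchanging the large 4-isopropoxy-3-methoxyphenyl for a plain phenyl, a 29-fold lower number from compound 1 to compound 2 (1.47 log units; beyond the scatter), moved it a great deal. Among the measured compounds shown here, the 2-hydroxyphenyl of compound 4 is a small ring like those of compound 2 and compound 3, and nothing among the measured compounds points to a large shift for it. A step of a 2.0-fold higher number from compound 3 to compound 4 (0.30 log units; within the scatter) is therefore expected, modest and within or close to the scatter. Compound 4 is estimated to give 400 nM, with a range from 150 nM to 1500 nM.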

Compound 4, half-maximal inhibitory concentration: 11500 nM
The estimate for compound 4 lay 29-fold (1.46 log units) below the measured number, and the stated range ends below it.
By their numbers in this assay, from the lowest: compounds 3 and 2 (each within the scatter of the next); then compounds 1 and 4 (each within the scatter of the next).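

The size of the ring at this position, on a carbon with a double bond to nitrogen, does not by itself keep the number low in this assay: 2-hydroxyphenyl in place of 4-chlorophenyl gives a 58-fold higher number from compound 3 to compound 4 (1.76 log units; beyond the scatter), although both groups have the same count of heavy atoms, and adding the hydroxy to the plain phenyl gives a 38-fold higher number from compound 2 to compound 4 (1.58 log units; beyond the scatter). The one added hydroxy thus moves the number far more than the chloro did in the earlier step, and it erases the gain seen with the small rings, since 2-hydroxyphenyl in place of the much larger 4-isopropoxy-3-methoxyphenyl gives a 1.3-fold higher number from compound 1 to compound 4 (0.12 log units; within the scatter). No measurement at hand explains why this single group has such a large effect.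

The compounds shown leave open whether the jump belongs to the hydroxy itself or to where it sits on the ring, as they include no second hydroxyphenyl for comparison. They also leave open whether a methoxy or an amine in place of that hydroxy would give a similarly high number or stay close to the plain phenyl.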